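Swapping fluoro for chloro on a low-clearance sulfone core

A few compounds are considered here, and "the series" means these few. Any claim that something is new, unique, unknown or untested is made for them only; others in the source may bear on it.

Measured compounds:
- compound 1, `COc1ccc(S(=O)(=O)c2cnc3c(F)cccc3c2-c2cccc(F)c2)cc1`, gives 3.03 mL/min in an ADME assay on microsomes from liver (Homo sapiens) for metabolic stability, tested at 2.5 uM; a lower number here means slower removal, a higher number faster removal of the compound
- compound 2, `COc1ccc(S(=O)(=O)c2cnc3c(F)cccc3c2-c2cccc(Cl)c2)cc1`, gives 2.75 mL/min in this assay
- compound 3, `O=S(=O)(c1cc(F)cc(F)c1)c1cnc2cc(F)ccc2c1-c1cccc(F)c1`, gives 0.06 mL/min in this assay

Compound 1 and compound 2 share one core and differ in a single spot: chloro in place of fluoro on an aromatic carbon. In this assay this change made a 1.1-fold lower number from compound 1 to compound 2 (0.04 log units; within the scatter), so the two numbers cannot be told apart by this measurement.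

Compound 3 sits on a different core. The difference between the two cores is not broken down here. In this assay compound 3 gives 0.06 mL/min, the lowest of the three numbers, and its distance from compound 1 and from compound 2 is beyond the scatter.

Compound 4, `O=S(=O)(c1cc(F)cc(F)c1)c1cnc2cc(F)ccc2c1-c1cccc(Cl)c1`, has not yet been measured. It is made from compound 3 by the same change that leads from compound 1 to compound 2: chloro in place of fluoro on an aromatic carbon. The place of the change reads the same in both pairs, so this is the same change on a second core.

Because a 1.1-fold lower number from compound 1 to compound 2 (0.04 log units; within the scatter) stayed within the scatter on the first core, the same change on the core of compound 3 is expected to give a step of about a 1.2-fold lower number from compound 3 to compound 4 (0.08 log units; within the scatter). Compound 4 is therefore estimated at 0.05 mL/min in this assay, expected to fall between 0.02 mL/min and 0.15 mL/min.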

Compound 4, intrinsic clearance in a liver preparation (reported as CLH), per the amount of preparation that the assay uses: 0.22 mL/min
The estimate for compound 4 lay 4.4-fold (0.64 log units) below the measured number, outside the stated range (above it).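

In this assay, chloro in place of fluoro on an aromatic carbon gave a 3.7-fold higher number from compound 3 to compound 4 (0.56 log units; beyond the scatter), so on this second core the swap produced a real change and not just measurement noise. The swap therefore did not carry over from one core to the other with the same size, and a step read on one core was a poor guide to the step on the other: the same change on two cores in this assay, a 1.1-fold lower number (0.04 log units; within the scatter) from compound 1 to compound 2 and a 3.7-fold higher number (0.56 log units; beyond the scatter) from compound 3 to compound 4, 4.0-fold (0.61 log units) apart, beyond the scatter of two such steps. Within the data shown here, with only two pairs, this shows that the effect of the swap depends on its surroundings, but it does not show which feature separating the two cores is responsible, why the steps differ, or what rule would hold across the wider series.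

The compounds shown leave open whether the swap on a third core would resemble the step on the core of compound 1 or the step on the core of compound 3. They also leave open how other groups would behave in the same place on either core, such as a nitrile or a trifluoromethyl group in place of the chloro.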